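A few compounds are considered here, and "the series" means these few. Any claim that something is new, unique, unknown or untested is made for them only; others in the source may bear on it.

The three measured compounds in an assay on mitochondria for inhibition of Amine oxidase [flavin-containing] B (Rattus norvegicus); on this read-out higher numbers stand for weaker inhibition and lower numbers for stronger inhibition:

Compound 1, `NC(=O)CNCc1ccc(OCc2cccc(F)c2)cc1`, gives 2240 nM.
Compound 2, `NC(=O)[C@@H](NCc1ccc(OCc2cccc(Cl)c2)cc1)c1ccccc1`, gives 10100 nM.
Compound 3, `NC(=O)[C@H](CO)NCc1ccc(OCc2cccc(Cl)c2)cc1`, gives 43 nM.

Among these three numbers compound 1 stands second highest. Its nearest neighbour is compound 2, whose number lies clearly higher, and its furthest is compound 3, whose number lies far lower. Compound 4, `NC(=O)[C@H](CO)NCc1ccc(OCc2cccc(F)c2)cc1`, has not yet been measured. It differs from compound 1 in a single place: hydroxymethyl in place of hydrogen on a saturated chain carbon bound to an amine nitrogen and a carbonyl carbon. The measured step that bears on this change is a 230-fold lower number from compound 2 to compound 3 (2.37 log units; beyond the scatter), where the same hydroxymethyl group enters at the same place, though there it replaces phenyl rather than hydrogen. Going by the values given here, compound 3 carries that same hydroxymethyl group, and compound 4 is its close relative, carrying fluorine where compound 3 carries chlorine, a difference for which no step has been measured here. On this ground a large step towards a lower number is expected, namely a 28-fold lower number from compound 1 to compound 4 (1.45 log units; beyond the scatter) in this assay. Compound 4 is therefore estimated at 80 nM, with a range from 25 nM to 300 nM.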

Compound 4, half-maximal inhibitory concentration: 140 nM
For compound 4 the middle estimate is 1.8-fold (0.24 log units) below the measured one, within the range that was stated.
By their numbers in this assay, from the lowest: compound 3; then compound 4; then compound 1; then compound 2.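

In this assay, hydroxymethyl in place of hydrogen on a saturated chain carbon bound to an amine nitrogen and a carbonyl carbon gives a 16-fold lower number from compound 1 to compound 4 (1.20 log units; beyond the scatter), so the lower number at this position does not depend on phenyl leaving, as it might have in the earlier step. Fluoro in place of chloro on an aromatic carbon gives a 3.3-fold higher number from compound 3 to compound 4 (0.51 log units; beyond the scatter), the first reading of this halogen change, and a smaller step than the hydroxymethyl one. Nothing available explains why either change moves the number.

The compounds shown leave open whether a methyl group, a 2-hydroxyethyl chain or a carboxylic acid at this position would lower the number as hydroxymethyl does. They also leave open how bromo would compare with fluoro and chloro on that aromatic carbon.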